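Swapping the arylidene aryl group on the shared core

A few compounds are considered here, and "the series" means these few. Any claim that something is new, unique, unknown or untested is made for them only; others in the source may bear on it.

Going by the values given here, compound 1 `O=C1/C(=C\c2ccc(F)cc2)c2ccccc2N1c1c(Cl)cccc1Cl` is the only member of this set with a numerical result: in a functional assay on MCF7 cells (Homo sapiens) for cytotoxicity, read by MTT assay, with a stated time of 72 h (on this read-out lower numbers stand for an effect already at smaller amounts and higher numbers for an effect only at larger amounts of compound), compound 1 gives 9 ug/mL. Compound 2 `Cc1ccc2nc(Cl)c(/C=C3\C(=O)N(c4c(Cl)cccc4Cl)c4ccccc43)cc2c1` carries a different aryl group on the same exocyclic carbon, and in this assay compound 2 reaches only > 100 ug/mL, which is a limit of the assay rather than a number; the limit of > 100 ug/mL in this assay, at which 1 of the 2 values shown sits, marks this. Compound 3 `O=C1/C(=C\c2c(Cl)cccc2Cl)c2ccccc2N1c1c(Cl)cccc1Cl` has not yet been tested. It differs from compound 1 in one place: 2,6-dichlorophenyl in place of 4-fluorophenyl on a double-bonded chain carbon bound to a double-bonded ring carbon. Among the compounds with values here, with only one number and one limit, the effect of altering this aryl group cannot be read from measured pairs, so any forecast is loosely held. The expected step of a 2.2-fold higher number from compound 1 to compound 3 (0.35 log units; beyond the scatter) is modest and toward a weaker effect, not far beyond the scatter. Compound 3 is therefore estimated to give 20 ug/mL in this assay, with a plausible range from 6 ug/mL to 70 ug/mL.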

Compound 3, concentration for half-maximal effect: > 100 ug/mL
Compound 3 gave a limit, no number; the forecaster's own chance of this, stated with the estimate: 25%; at least 5.0-fold (0.69 log units) between middle value and limit.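

In this assay, going by these compounds alone, placing 2,6-dichlorophenyl where compound 1 has 4-fluorophenyl, on a double-bonded chain carbon bound to a double-bonded ring carbon, gives an at least 11-fold higher number from compound 1 to compound 3 (1.04 log units; beyond the scatter), the first step at this position that can be read. It shows that this position is not indifferent to the aryl group: even with a six-membered aromatic ring of carbon only on both sides of the change, exchanging fluorine for two chlorines is enough to leave no number in this assay. The size of the step is a bound rather than a measured gap, and compound 1 still holds the only number: the limit of > 100 ug/mL in this assay, at which 2 of the 3 values shown sit.

The compounds shown leave open whether the fluorine itself matters to the number of compound 1 or whether plain phenyl would serve as well. They also leave open how an aryl group carrying an amine or a carboxylic acid would read out on the shared core.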